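This account rests on a few compounds, and the source may have more. Where it says the series, first, only, none or still open, it means among the compounds named here.

Compound 1 (`COc1cc2ncnc(-n3nc(-c4ccccn4)nc3N)c2cc1OCCCN(C)C`), compound 2 (`COc1cc2ncnc(-n3nc(-c4ccccn4)nc3N)c2cc1OCCCN1CC(C)OC(C)C1`) and compound 3 (`COc1cc2ncnc(-n3nc(-c4ccccn4)nc3N)c2cc1OCCCNC(=O)OCC(F)(F)F`) share one core and differ only at the end of a saturated chain. All three were tested in an ADME assay on BJ cells (Homo sapiens) for cytotoxicity, with a stated time of 72 h (a higher number here means that more compound is needed for the effect, a lower number that less compound is needed), and none gave a true number. Compound 1 sits at > 25000 nM as a limit. Compound 2 sits at > 25000 nM as a limit too. As far as these compounds go, compound 3 stands at > 11000 nM and this is also a limit, so its real position is unknown.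

The change trifluoromethyl in place of 2,2,2-trifluoroethoxy on a carbonyl carbon puts trifluoromethyl in place of 2,2,2-trifluoroethoxy on a carbonyl carbon and gives compound 4 (`COc1cc2ncnc(-n3nc(-c4ccccn4)nc3N)c2cc1OCCCNC(=O)C(F)(F)F`). The measured steps that bear on this all concern the same chain end, and none has a readable size: a step that the two limits leave unreadable from compound 1 to compound 3 and a step that the two limits leave unreadable from compound 2 to compound 3 and also a step that the two limits leave unreadable from compound 1 to compound 2 are all that can be drawn on.

With compound 3 and its limit of > 11000 nM as the only anchor, no shift beyond the scatter is expected in this assay for this change. The expected step is a step that the limit leaves unreadable from compound 3 to compound 4 and it is only an estimate. For compound 4 the estimated value is 20000 nM with an expected range from 10000 nM to 40000 nM and a strong chance of a limit instead of a number.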

Compound 4, half-maximal effective concentration: > 7000 nM
Compound 4: a limit, no number; the forecaster's own chance of this, stated with the estimate: 85%; the middle value is on the limit's open side.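

Among the compounds shown here, compound 4, like compound 1, compound 2 and compound 3, gives only a limit in this assay, so no step among them can be read. The compounds shown leave open where any of the four truly stands, and whether trifluoromethyl in place of 2,2,2-trifluoroethoxy changes anything.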